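Phenyl for Pyridin-2-yl on the Sulfonamide Nitrogen

The compounds below may be only part of what the source reports. "The series", "measured", "known", "first", "only" and "open" are said of these compounds alone.

Compound 1 `O=S(=O)(Nc1ccccn1)c1ccc2nc(-c3ccccc3)c(-c3ccccc3)nc2c1` carries a pyridin-2-yl group on its sulfonamide nitrogen. In an ADME assay on the whole organism for pharmacokinetics, with Homo sapiens as the target (on this read-out lower numbers stand for lower oral bioavailability and higher numbers for higher oral bioavailability), compound 1 gives 100%. Compound 2 `O=S(=O)(Nc1cccc2ccccc12)c1ccc2nc(-c3ccccc3)c(-c3ccccc3)nc2c1` carries a naphthalen-1-yl group at the same place, and in this assay compound 2 gives 100%. The step of no change at the digits printed from compound 1 to compound 2 (within the scatter) shows that swapping the group on the sulfonamide nitrogen left the read-out unchanged, so compound 1 stands level with compound 2 on the numbers at hand.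

Compound 3 `O=S(=O)(Nc1ccccc1)c1ccc2nc(-c3ccccc3)c(-c3ccccc3)nc2c1` has not yet been measured. It differs from compound 1 thus: phenyl in place of pyridin-2-yl on a sulfonamide nitrogen. For the measured compounds named here, the only measured step at this place, no change at the digits printed from compound 1 to compound 2 (within the scatter), exchanged the same pyridin-2-yl for another aromatic group without a change beyond the scatter, so the step to phenyl is expected to stay within the scatter as well, namely no change at the digits printed from compound 1 to compound 3 (within the scatter). Since compound 1 gives 100%, compound 3 is estimated at 100%, in a range from 85% to 100%.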

Compound 3, oral bioavailability: 100%
Beside the measured number, compound 3's estimate shows no gap at the digits printed, and the stated range covers the measured number.
By their numbers in this assay, from the lowest: compounds 1, 2 and 3 (each within the scatter of the next).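

In this assay, the step to phenyl gives no change at the digits printed from compound 1 to compound 3 (within the scatter), so on the sulfonamide nitrogen a six-membered aromatic ring of carbon only reads the same as one with a hetero atom. The second new step, no change at the digits printed from compound 2 to compound 3 (within the scatter), shows that the single carbon ring and naphthalen-1-yl also stand level, so all three aromatic groups at this place read alike, and none of the compounds goes against this. Nothing at hand bears on why the read-out stays the same across these groups.

All three compounds carry an aromatic group at this place, which leaves open how this assay reads with a cyclohexyl group or an ethyl chain on the sulfonamide nitrogen. Also open, going by these compounds, is what a carboxylic acid or an amine on the phenyl ring would do.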